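The source may report more compounds than this note shows. Statements on the series, on what has been measured and on what is new or still open speak of the compounds shown alone.

Within the data shown here, compound 1 `Cc1ccccc1-c1nc(CN2CCC(C(=O)NCCCN3CCCCC3)CC2)c(C)o1` is one of two compounds measured in an ADME assay on Huh7.5.1 cells (Homo sapiens) for cytotoxicity, read by ATP content, with a stated time of 48 h (on this read-out higher numbers stand for lower toxicity in this test and lower numbers for higher toxicity in this test), where compound 1 gives 18100 nM. Among the measured compounds shown here, compound 2 `Cc1oc(-c2c(Cl)cccc2Cl)nc1CN1CCC(C(=O)NCCCN2C[C@H](C)C[C@H](C)C2)CC1` gives 13200 nM in this assay, a number that lies within the usual scatter of the one for compound 1, so the two cannot be told apart. Compound 3 `CCCN(CCC)CCNC(=O)C1CCN(Cc2nc(-c3ccccc3C)oc2C)CC1` is not yet measured. It differs from compound 1 in one place: dipropylamino in place of (piperidin-1-yl)methyl on a saturated chain carbon, two bonds along the chain from an amide-type nitrogen. For the measured compounds named here, with no measured step of this kind to lean on, the change from compound 1 to compound 3 is expected to stay within the scatter, a 1.1-fold lower number from compound 1 to compound 3 (0.05 log units; within the scatter). For compound 3 the estimate is 16000 nM, between 7000 nM and 36000 nM.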

Compound 3, half-maximal cytotoxic concentration: 30500 nM
Beside the measured number, compound 3's estimate is 1.9-fold (0.28 log units) below it; the measured number falls inside the stated range.
By their numbers in this assay, from the lowest: compounds 2, 1 and 3 (each within the scatter of the next, the first and the last beyond it).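

In this assay the first step measured at this position, dipropylamino in place of (piperidin-1-yl)methyl, stays within the scatter (a 1.7-fold higher number from compound 1 to compound 3 (0.23 log units; within the scatter)). So on a saturated chain carbon, two bonds along the chain from an amide-type nitrogen, a group with no ring and a group with one six-membered non-aromatic ring cannot be told apart in this test. Nothing at hand offers an explanation for this result. Still open, from the compounds shown here alone, is whether a morpholin-4-yl group or a carboxylic acid in this place would give a number beyond the scatter of compound 1.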